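Replacing the Chlorophenyl Group on a Glycine Transporter Inhibitor

This account rests on a few compounds, and the source may have more. Where it says the series, first, only, none or still open, it means among the compounds named here.

Of the compounds shown here, three have been measured in an assay on cells for inhibition of sodium- and chloride-dependent glycine transporter 1 (Homo sapiens); a lower number here means that less compound is needed, a higher number that more compound is needed for the effect. Compound 1 `COc1cc(C(F)(F)F)cc(C(F)(F)F)c1C(=O)NC1(c2ccccc2)CCCN(Cc2ccccc2)C1` gives 6700 nM, compound 2 `COc1cccc(C(F)(F)F)c1C(=O)NC1(c2ccccc2)CCCN(C)C1` gives 1500 nM, and compound 3 `COc1cc(C(F)(F)F)cc(SC)c1C(=O)NC1(c2ccc(Cl)cc2)CCCN(C)C1` gives 28 nM, the lowest number of the three, so compound 3 needs the least material; its nearest neighbour, compound 2, lies well beyond the scatter above it. Compound 4 `COc1cc(C(F)(F)F)cc(SC)c1C(=O)NC1(c2ncccn2)CCCN(C)C1` has not yet been measured. It differs from compound 3 in one place: pyrimidin-2-yl in place of 4-chlorophenyl on a saturated ring carbon. For the measured compounds named here, no measured pair shows this kind of exchange, so the expectation rests on compound 3 alone. The step of a 3.2-fold higher number from compound 3 to compound 4 (0.51 log units; beyond the scatter) is expected to be a modest rise in the number, somewhat beyond the scatter. Compound 4 is therefore estimated at 90 nM, within a range of 25 nM to 350 nM.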

Compound 4, half-maximal effective concentration: > 10000 nM
Compound 4 ended at the assay's limit (the forecaster's own chance of this, stated with the estimate: 3%); at least 110-fold (2.04 log units) between middle value and limit.
By their numbers in this assay, from the lowest: compound 3; then compound 2; then compound 1. At a limit, above all of these: compound 4.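

Exchanging 4-chlorophenyl for pyrimidin-2-yl on this saturated ring carbon gives an at least 350-fold higher number from compound 3 to compound 4 (2.55 log units; beyond the scatter), so at this position one six-membered aromatic ring cannot simply stand in for another. For compound 4 this is a limit of the assay and not a number, so the full size of the step stays unknown: the limit of > 10000 nM in this assay, at which 1 of the 4 values shown sits.

The compounds shown leave open whether the loss goes with the chlorine or with the ring nitrogens, as this change alters both at once. A plain phenyl or a pyridin-2-yl group on this carbon, with the rest of compound 3 kept, would separate the two.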